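A few compounds are considered here, and "the series" means these few. Any claim that something is new, unique, unknown or untested is made for them only; others in the source may bear on it.

Three compounds built on one shared core have been run through an ADME assay on Huh-7 cells (Homo sapiens) for cytotoxicity, read by a luciferase reporter and WST assay, with a stated time of 3 days; a lower number here means that less compound is tolerated, a higher number that more compound is tolerated. Compound 1 `O=C(Nc1ccccc1)c1c(NO)cc(-c2ccc(Cl)cc2)oc1=O` gives 11000 nM in this assay. Compound 2 `O=C(Nc1ccc(Br)cc1)c1c(NO)cc(-c2ccccc2)oc1=O` reaches only the limit of the measurement, > 20000 nM, so a limit rather than a number is all that is known for it. Compound 3 `Cc1ccc(NC(=O)c2c(NO)cc(-c3ccc(C)cc3)oc2=O)cc1` likewise stops at a limit, > 20000 nM. Compound 2 therefore stands at the limit of > 20000 nM in this assay, at which 2 of the 3 values shown sit; it cannot be ranked against compound 1, which is the only one of the three with a true number. Compound 4 `O=C(NCc1ccccc1)c1c(NO)cc(-c2ccccc2)oc1=O` has not yet been measured in this assay. It differs from compound 2 in one place: benzyl in place of 4-bromophenyl on an amide-type nitrogen. Going by the values given here, no measured pair here changes at that position alone, so there is nothing to set the size of this step against. The expected step is a number no higher from compound 2 to compound 4 (the limit leaves the size open), none beyond the usual scatter, with a good chance that the assay again returns only a limit. Compound 4 is accordingly estimated to give 20000 nM, between 10000 nM and 40000 nM.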

Compound 4, half-maximal cytotoxic concentration: > 20000 nM
Compound 4 gave a limit, no number; the forecaster's own chance of this, stated with the estimate: 60%; the middle value sits exactly at the limit.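

Compound 2 and compound 4 both end at a limit rather than a true number, so no step can be read between them: the limit of > 20000 nM in this assay, at which 3 of the 4 values shown sit. The compounds shown leave open how much benzyl in place of 4-bromophenyl on an amide-type nitrogen changes the tolerated concentration, if at all.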